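Swapping the amine on a dithiocarbamate-linked benzamide

The source may hold more compounds than are shown below. What is called first, only, known or untested is meant among the compounds shown, and "the series" means these compounds.

The series shares one core, seen in compound 1 `Nc1ccccc1NC(=O)c1ccc(CSC(=S)N2CCN(C3CCCCC3)CC2)cc1`, with a dithiocarbamate sulfur carrying different amines. In a functional assay on A-375 cells (Homo sapiens) for antiproliferative activity, read by CCK-8 assay, with a stated time of 72 h, tested at 8 uM (a lower number here means a weaker effect, a higher number a stronger effect of the compound at the concentration tested), compound 1 gives 89.9%, compound 2 `Nc1ccccc1NC(=O)c1ccc(CSC(=S)N2CCc3cc([N+](=O)[O-])ccc32)cc1` gives 29.5%, and compound 3 `CC1CCCCN1C(=S)SCc1ccc(C(=O)Nc2ccccc2N)cc1` gives 85.2%. Compound 3 thus sits second of the three; its number and that of compound 1 lie within the scatter, while compound 2 lies clearly lower, beyond the scatter. Compound 4 `Nc1ccccc1NC(=O)c1ccc(CSC(=S)N2CCCc3ccccc32)cc1` carries 1,2,3,4-tetrahydroquinolin-1-yl in place of 2-methylpiperidin-1-yl on a thiocarbonyl carbon. For the measured compounds named here, no measured pair isolates this change. The only other aromatic-bearing amine, in compound 2, scores low, so a downward step of moderate size is expected from compound 3 to compound 4, a number 25.2 percentage points lower from compound 3 to compound 4 (beyond the scatter). Compound 4 is therefore estimated at 60% in this assay, within a wide range from 25% to 90%.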

Compound 4, a percentage reported as inhibition, at one concentration (the size of the read-out at that concentration, not a potency): 81.5%
Compound 4: the middle estimate sits 21.5 percentage points below what was measured; low and high end bracket the measured number.
By their numbers in this assay, from the lowest: compound 2; then compounds 4, 3 and 1 (each within the scatter of the next).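

In this assay, for the compounds shown here, 1,2,3,4-tetrahydroquinolin-1-yl in place of 2-methylpiperidin-1-yl on a thiocarbonyl carbon gives a number 3.7 percentage points lower from compound 3 to compound 4 (within the scatter), the first step that isolates one change. At this position, a six-membered aromatic ring of carbon only therefore enters without moving the read-out beyond the scatter. Nothing measured here gives a reason for this result.

Going by these compounds, compound 2 differs from compound 4 in more than one place, so the part played by its nitro group stays open. On these data alone, how a morpholine would score on the thiocarbonyl carbon also stays open.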